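Swapping the cyclohexyl ring for an open amine chain

This account rests on a few compounds, and the source may have more. Where it says the series, first, only, none or still open, it means among the compounds named here.

Compound 1 `Nc1cccc(Nc2c(C(=O)NCc3ccc(F)cc3)nc(Br)c3cccnc23)c1`: > 10000 nM (a limit)
Compound 2 `N[C@H]1CC[C@H](Nc2c(C(=O)NCc3ccc(F)cc3)nc(Br)c3cccnc23)CC1`: 2000 nM

The series is followed in a functional assay on SK-BR-3 cells (Homo sapiens) for cytotoxicity, read by MTT assay, with a stated time of 72 h; on this read-out higher numbers stand for weaker inhibition and lower numbers for stronger inhibition. There, compound 1 gives > 10000 nM, which is a limit of the assay and not a number. Going by the values given here, compound 2, at 2000 nM, holds the only true number so far, so no ranking beyond that single comparison is possible.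

The next compound is compound 3 `CNCCCNc1c(C(=O)NCc2ccc(F)cc2)nc(Br)c2cccnc12`, which carries 3-(methylamino)propyl in place of 4-aminocyclohexyl on a nitrogen on an aromatic ring. Among the compounds with values here, only one measured step bears on this place: an at least 5.0-fold lower number from compound 1 to compound 2 (0.69 log units; beyond the scatter). That step replaced an aromatic ring with a non-aromatic one, and it is beyond the scatter. It does not show what an open chain will do, yet compound 3 also has no aromatic ring there, so compound 2 remains the closest guide. The expected change is a 1.3-fold higher number from compound 2 to compound 3 (0.10 log units; within the scatter), which is not expected to exceed the scatter. For compound 3 the estimated value is 2500 nM, with an expected range of 700 nM to 9000 nM.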

Compound 3, half-maximal inhibitory concentration: 1000 nM
For compound 3 the middle estimate is 2.5-fold (0.40 log units) above the measured one; measured number inside the range.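

In this assay, the ring at this place proves not to be required: a 2.0-fold lower number from compound 2 to compound 3 (0.30 log units; within the scatter), a step within the scatter, so 3-(methylamino)propyl, with no ring and no defined stereocentres, cannot be told apart from 4-aminocyclohexyl. The earlier step compared two ring groups, whereas the new comparison with the aromatic group, an at least 10-fold lower number from compound 1 to compound 3 (1.00 log units; beyond the scatter), lies beyond the scatter and points the same way, so among these three compounds both groups without an aromatic ring give lower numbers than 3-aminophenyl. The size of that step is only a bound, as the value of compound 1 is a limit of the assay and not a number, and the bound rests on this: the limit of > 10000 nM in this assay, at which 1 of the 3 values shown sits.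

The compounds shown leave open whether the amine in these groups matters at all, since compound 1, compound 2 and compound 3 each carry one, and a chain ending in a hydroxyl group would speak to that. They also leave open how a shorter or longer chain, or a primary or dimethylamino end in place of the methylamino end, would read in this assay on this shared core.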